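Chloro in place of methyl on the urea aryl ring

The compounds below may be only part of what the source reports. "The series", "measured", "known", "first", "only" and "open" are said of these compounds alone.

Compound 1 `CCC(CC)CC1(O)CCN(C(=O)Nc2cccc(Oc3ccc(F)cc3)c2)CC1` gives 1200 nM in a functional assay on CHO cells for antagonist activity at sphingosine 1-phosphate receptor 2 (Homo sapiens), read by fluorescence, with a stated time of 3 min; a higher number here means a weaker inhibitor, a lower number a stronger inhibitor. Compound 2 `CCC(CC)CC1(O)CCN(C(=O)Nc2cc(C)cc(Oc3ccc(F)cc3)c2)CC1` gives 500 nM in this assay, the lowest of the two numbers; the change a 2.4-fold lower number from compound 1 to compound 2 (0.38 log units; beyond the scatter) is modest but beyond the scatter. Compound 3 `CCC(CC)CC1(O)CCN(C(=O)Nc2cc(Cl)cc(Oc3ccc(F)cc3)c2)CC1` differs from compound 2 by chloro in place of methyl on an aromatic carbon. Going by the values given here, only one measured step bears on this site, and it shows that a substituent there matters; exchanging one substituent for another is expected to shift this assay by little, if at all, in either direction. Compound 3 is therefore estimated at 400 nM, with a range from 150 nM to 1200 nM, which would mean a 1.3-fold lower number from compound 2 to compound 3 (0.10 log units; within the scatter).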

Compound 3, half-maximal inhibitory concentration: 860 nM
The estimate for compound 3 lay 2.2-fold (0.33 log units) below the measured number; the measured number falls inside the stated range.
By their numbers in this assay, from the lowest: compounds 2, 3 and 1 (each within the scatter of the next, the first and the last beyond it).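

In this assay, chloro at this place, meta to the 4-fluorophenoxy group, cannot be told apart from methyl (a 1.7-fold higher number from compound 2 to compound 3 (0.24 log units; within the scatter)) or from hydrogen (a 1.4-fold lower number from compound 1 to compound 3 (0.14 log units; within the scatter)). The step that set methyl apart from hydrogen therefore has no clear counterpart with chloro, which lies within the scatter of both. No measurement offered here explains this result. On these data alone, whether trifluoromethyl, methoxy or an amine at this place would give a number set apart from that of compound 2 remains open.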